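Swapping Phenyl for Thiophene on a Nucleoside Core

The source may hold more compounds than are shown below. What is called first, only, known or untested is meant among the compounds shown, and "the series" means these compounds.

In a functional assay on CEM-DNR-bulk cells (Homo sapiens), read by MTT assay, with a stated time of 72 h (on this read-out lower numbers stand for stronger inhibition and higher numbers for weaker inhibition), compound 1 `C#Cc1cn([C@@H]2O[C@H](CO)[C@@H](O)[C@H]2O)c2ncnc(C)c12` gives 160 nM. Compound 2 `O=c1[nH]cnc2c1c(-c1cccs1)cn2[C@@H]1O[C@H](CO)[C@@H](O)[C@H]1O` reaches only the limit of this assay, > 20000 nM. Compound 3 `COc1nc(N)nc2c1c(-c1ccccc1)cn2[C@@H]1O[C@H](CO)[C@@H](O)[C@H]1O` likewise reaches only the limit, > 20000 nM, which places it at the limit of > 20000 nM in this assay, at which 2 of the 3 values shown sit, so no number for compound 3 is known. Compound 4 `COc1nc(N)nc2c1c(-c1cccs1)cn2[C@@H]1O[C@H](CO)[C@@H](O)[C@H]1O` differs from compound 3 in one place: thiophen-2-yl in place of phenyl on an aromatic carbon. For the measured compounds named here, no step between measured compounds shares this change, so nothing in the numbers so far sets its size. Compound 2, which carries the same thiophen-2-yl group on a different core, also sits at the limit. Compound 4 is therefore expected to remain weak, with a step that the limit leaves unreadable from compound 3 to compound 4 that means no movement beyond the scatter. The estimate for compound 4 is 25000 nM, between 8000 nM and 60000 nM.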

Compound 4, half-maximal inhibitory concentration: > 20000 nM
Compound 4 gave a limit, no number (the forecaster's own chance of this, stated with the estimate: 80%); the middle value does not contradict the limit.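

For the compounds shown here, neither compound 3 nor compound 4 gives a number in this assay, only a limit, so no step between them can be read: the limit of > 20000 nM in this assay, at which 3 of the 4 values shown sit. From the compounds shown here alone, whether thiophen-2-yl and phenyl differ at all on this shared core stays open.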